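This account rests on a few compounds, and the source may have more. Where it says the series, first, only, none or still open, it means among the compounds named here.

Measured so far in an ADME assay on MT4 cells (Homo sapiens) for cytotoxicity, read by MTT assay; a lower number here means that less compound is tolerated, a higher number that more compound is tolerated:
- compound 1 `CC(C)NC(=O)C1C(=O)N(O)C(=O)c2ccccc21` gives 163000 nM
- compound 2 `CC(C)(C)NC(=O)C1C(=O)N(O)C(=O)c2ccccc21` gives 142000 nM

Going by the values given here, compound 2 lies within the scatter of compound 1, the only other compound measured, so the two cannot be ranked. Compound 3 `CCCCCCCCNC(=O)C1C(=O)N(O)C(=O)c2ccccc21`, not yet measured, carries octyl in place of tert-butyl on an amide-type nitrogen. Among the compounds with values here, one measured step bears on this change (a 1.1-fold lower number from compound 1 to compound 2 (0.06 log units; within the scatter)), and it swaps only a hydrogen for a methyl. The octyl change is much larger, so that small step says little about it. No straight chain of this length has been measured, which leaves the direction a judgment: a lower number is expected in this assay for the longer chain. The expected size is an estimate (a 3.6-fold lower number from compound 2 to compound 3 (0.55 log units; beyond the scatter)). Compound 3 is estimated at 40000 nM with an expected range from 10000 nM to 140000 nM for repeat measurements.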

Compound 3, half-maximal cytotoxic concentration: 98500 nM
Estimate against measurement, compound 3: 2.5-fold (0.39 log units) below; the measured number falls inside the stated range.
By their numbers in this assay, from the lowest: compounds 3, 2 and 1 (each within the scatter of the next).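

In this assay, octyl in place of tert-butyl on an amide-type nitrogen gives a 1.4-fold lower number from compound 2 to compound 3 (0.16 log units; within the scatter), and octyl in place of isopropyl gives a 1.7-fold lower number from compound 1 to compound 3 (0.22 log units; within the scatter). The earlier step added only a single methyl, whereas these changes bring in a much longer straight chain, and still all three compounds remain too close to rank, so this position tolerates a large change in the carbon group without a readable shift across these compounds. No supporting measurement is available to explain this outcome.

The compounds shown leave open whether a chain bearing an amine or a carboxylic acid on this nitrogen would move the number beyond the scatter. They also leave open whether a longer chain than octyl would stay within it.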